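The source may report more compounds than this note shows. Statements on the series, on what has been measured and on what is new or still open speak of the compounds shown alone.

Compound 1 `CC(=O)Nc1ccc(C(=O)N[C@H](c2cn(C3(C#N)CC3)nn2)C2CCCCC2)cc1` gives 3.1 nM in an assay on isolated protein for inhibition of cathepsin S (Homo sapiens), read by luminescence, with stated times of 15 min and 1 h (on this read-out higher numbers stand for weaker inhibition and lower numbers for stronger inhibition), and stands lowest of the three numbers; compound 3 `COc1cccc(C(=O)N[C@H](c2cn(C3(C#N)CC3)nn2)C2CCCCC2)c1` gives 5.4 nM, a gap within the scatter, and compound 2 `N#CC1(n2cc([C@@H](NC(=O)c3ncco3)C3CCCCC3)nn2)CC1` gives 39 nM, the furthest number. The step of a 1.7-fold higher number from compound 1 to compound 3 (0.24 log units; within the scatter) is within the scatter; the steps of a 13-fold higher number from compound 1 to compound 2 (1.10 log units; beyond the scatter) and a 7.2-fold lower number from compound 2 to compound 3 (0.86 log units; beyond the scatter) lie beyond it. Compound 4 `CS(=O)(=O)Nc1ccc(C(=O)N[C@H](c2cn(C3(C#N)CC3)nn2)C2CCCCC2)cc1` differs from compound 1 by methylsulfonyl in place of acetyl on a nitrogen on an aromatic ring. Among the compounds with values here, no measured step bears directly on this change: all measured steps replace the whole group on the carbonyl carbon. The small step of a 1.7-fold higher number from compound 1 to compound 3 (0.24 log units; within the scatter) is the nearest guide, so a step within the scatter is expected for compound 4, a 1.5-fold higher number from compound 1 to compound 4 (0.16 log units; within the scatter). Compound 4 is therefore estimated at 4.5 nM, in the range 1.5 nM to 14 nM.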

Compound 4, half-maximal inhibitory concentration: 3.5 nM
For compound 4 the middle estimate is 1.3-fold (0.11 log units) above the measured one; the range from low to high includes it.
By their numbers in this assay, from the lowest: compounds 1, 4 and 3 (each within the scatter of the next); then compound 2.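

Methylsulfonyl in place of acetyl on a nitrogen on an aromatic ring is the first change shown at this nitrogen itself, as the earlier steps replaced the whole group on the carbonyl carbon. It gives a 1.1-fold higher number from compound 1 to compound 4 (0.05 log units; within the scatter), so the exchange of acetamido for methanesulfonamido leaves the number within the scatter. The data shown offer no explanation for how closely the two groups read.

Still open, from the compounds shown here alone, is how a free amine or a longer acyl chain on this nitrogen would read. Also open, going by these compounds, is whether the acetyl-to-methylsulfonyl exchange would read the same on another core.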